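This account rests on a few compounds, and the source may have more. Where it says the series, first, only, none or still open, it means among the compounds named here.

Measured so far in a functional assay on DU-145 cells (Homo sapiens) for cytotoxicity (a higher number here means a weaker inhibitor of growth, a lower number a stronger inhibitor of growth), for the series:

compound 1 `COc1ccc(C2=C(c3ccc(SC)cc3)CC3CCCN3C2=O)cc1C` gives 900 nM as its value
compound 2 `CSc1ccc(C2=C(c3ccc(O)c(O)c3)C(=O)N3CCCC3C2)cc1` gives 60000 nM as its value
compound 3 `CSc1ccc(C2=C(c3ccc(F)cc3)C(=O)N3CCCC3C2)cc1` gives 500 nM as its value

Compound 3 stands at the low end of these numbers, in company with one other compound: a 1.8-fold lower number from compound 1 to compound 3 (0.26 log units; within the scatter) is a step inside the scatter, whereas a 120-fold lower number from compound 2 to compound 3 (2.08 log units; beyond the scatter) is a large one.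

Next is compound 4 `CSc1ccc(C2=C(c3ccc(SC)cc3)C(=O)N3CCCC3C2)cc1` with its difference from compound 3 given by methylsulfanyl in place of fluoro on an aromatic carbon in the form of methylsulfanyl in place of fluoro on an aromatic carbon, para to a large group.

Exchanges on the same double-bonded ring carbon bear on this. There, 4-fluorophenyl and 4-methoxy-3-methylphenyl gave the step inside the scatter, while 3,4-dihydroxyphenyl gave a 67-fold higher number from compound 1 to compound 2 (1.82 log units; beyond the scatter) as a large rise. No hydroxy group enters in compound 4, so the first of these exchanges is the closer guide.

In this assay no step beyond the scatter is expected, and no clear direction. The expected step is a 1.4-fold higher number from compound 3 to compound 4 (0.15 log units; within the scatter) on this estimate.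

Compound 4 is estimated at 700 nM with an expected range of 200 nM to 2500 nM in this series.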

Compound 4, concentration for 50% growth inhibition: 8000 nM
Compound 4: middle estimate off by 11-fold (1.06 log units), on the low side, and the stated range ends below it.
By their numbers in this assay, from the lowest: compounds 3 and 1 (each within the scatter of the next); then compound 4; then compound 2.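

In this assay, this double-bonded ring carbon proves sensitive to a change at the far end of its aryl group: methylsulfanyl in place of fluoro gives a large rise (a 16-fold higher number from compound 3 to compound 4 (1.20 log units; beyond the scatter)), whereas the exchange of 4-fluorophenyl for 4-methoxy-3-methylphenyl had stayed inside the scatter. 4-(Methylsulfanyl)phenyl also gives a higher number than 4-methoxy-3-methylphenyl (an 8.9-fold higher number from compound 1 to compound 4 (0.95 log units; beyond the scatter)) but a lower one than 3,4-dihydroxyphenyl (a 7.5-fold lower number from compound 2 to compound 4 (0.88 log units; beyond the scatter)), so the aryl groups here now fall into three separate levels rather than two. No measurement at hand accounts for the rise with methylsulfanyl.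

From the compounds shown here alone, it remains open whether the rise follows the sulfur itself or its methyl group, which a methoxy or ethylsulfanyl group in the same place would help separate. Going by these compounds, how an amine or a carboxylic acid would behave there also remains open.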